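A few compounds are considered here, and "the series" means these few. Any claim that something is new, unique, unknown or untested is made for them only; others in the source may bear on it.

Of the compounds shown here, three have so far been measured in a functional assay on A-431 cells (Homo sapiens) for inhibition, read by MTT assay, with a stated time of 72 h; on this read-out higher numbers stand for weaker inhibition and lower numbers for stronger inhibition. Compound 3 `C=CC(=O)Nc1cccc(Oc2nc(Nc3cccc(OC)c3)nc3ccsc23)c1` gives 4790 nM, the lowest of the three numbers. Compound 1 `COc1ccc(Nc2nc(Oc3cccc(NC(=O)C=C(C)C)c3)c3sccc3n2)cc1` gives 17600 nM, and compound 2 `COc1ccc(Nc2nc(Oc3cccc(NC(=O)/C=C/C(C)C)c3)c3sccc3n2)cc1` gives 25200 nM; both stand beyond the scatter away from compound 3. For the measured compounds named here, the only step between compounds that differ in a single place, a 1.4-fold higher number from compound 1 to compound 2 (0.16 log units; within the scatter), swaps one branched group for another on the carbonyl carbon and shows no change that counts.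

Compound 4 `C/C=C/C(=O)Nc1cccc(Oc2nc(Nc3cccc(OC)c3)nc3ccsc23)c1` has not been measured. It differs from compound 3 by prop-1-en-1-yl in place of vinyl on a carbonyl carbon. Going by the values given here, no measured step covers this exact change. The step from compound 1 to compound 2 bears on it only loosely, showing that reshaping an already enlarged group on that carbonyl carbon moves this assay little. Because compound 1 gives 17600 nM and compound 2 gives 25200 nM, both carrying larger groups on that carbonyl carbon than compound 3 does, although they differ from it elsewhere as well, a longer group there is expected to raise the number. The step of a 2.3-fold higher number from compound 3 to compound 4 (0.36 log units; beyond the scatter) is therefore expected to be modest and toward weaker inhibition. Compound 4 is expected to give 11000 nM, within a range from 4000 nM to 32000 nM.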

Compound 4, half-maximal inhibitory concentration: 13100 nM
Compound 4: middle estimate off by 1.2-fold (0.08 log units), on the low side, within the range that was stated.
By their numbers in this assay, from the lowest: compound 3; then compounds 4, 1 and 2 (each within the scatter of the next).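

In this assay, for the compounds shown here, the step of a 2.7-fold higher number from compound 3 to compound 4 (0.44 log units; beyond the scatter) is the first measured change at this carbonyl carbon that starts from vinyl, with the rest of the molecule held constant. It shows that the amide-bound group does matter here: putting prop-1-en-1-yl in place of vinyl moves the number toward weaker inhibition by more than the usual scatter of repeated measurements, whereas the earlier step of a 1.4-fold higher number from compound 1 to compound 2 (0.16 log units; within the scatter), which swapped one enlarged group for another, stayed within that scatter. No measurement available here explains why this shift occurs.

From the compounds shown here alone, only a few groups at this position have been compared, so it remains open whether a longer chain on the carbonyl carbon would raise the number further, or whether a chain ending in a dimethylamino group would behave differently from the plain carbon groups seen so far. It is also unknown whether vinyl would give a similar advantage on the rest of the structure found in compound 1, since no pair of compounds shown tests this change there.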